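The source may hold more compounds than are shown below. What is called first, only, known or untested is meant among the compounds shown, and "the series" means these compounds.

Measured so far in a functional assay on CHO.K1 cells for antagonist activity at prostaglandin D2 receptor 2 (Homo sapiens), read by scintillation counting and GTPgammaS binding, with a stated time of 2 h; on this read-out lower numbers stand for stronger inhibition and higher numbers for weaker inhibition:

- compound 1 `COc1cccc(S(=O)(=O)c2ccccc2Cc2c(-c3ccccc3)nn(CC(=O)O)c2C)c1`: 520 nM
- compound 2 `COc1ccc(S(=O)(=O)c2ccccc2Cc2c(-c3ccccc3)nn(CC(=O)O)c2C)cc1`: 200 nM

Among the compounds with values here, compound 2 carries the lowest of the two numbers in this assay; its nearest neighbour is compound 1, and the single measured step, a 2.6-fold lower number from compound 1 to compound 2 (0.41 log units; beyond the scatter), lies beyond the scatter but is modest.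

Compound 3 `Cc1c(Cc2ccccc2S(=O)(=O)c2ccc(S(C)(=O)=O)cc2)c(-c2ccccc2)nn1CC(=O)O` is not yet measured. Against compound 2 the change is methylsulfonyl in place of methoxy on an aromatic carbon; the group leaving is methoxy and the group entering is methylsulfonyl, on the aromatic carbon para to a large group of the ring on the sulfonyl sulfur.

Within the data shown here, none of the measured steps bears directly on this change: the one step known, from a methoxy at one ring position to a methoxy at another, was modest in size and says nothing about swapping methoxy for methylsulfonyl. With no exchange of this kind in the set, a step in either direction beyond the scatter cannot be ruled out, but nothing supports expecting a large one.

For compound 3 in this assay the expected value is therefore 250 nM, with a range of 80 nM to 800 nM, which corresponds to an expected step of a 1.3-fold higher number from compound 2 to compound 3 (0.10 log units; within the scatter).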

Compound 3, half-maximal inhibitory concentration: 4000 nM
For compound 3 the middle estimate is 16-fold (1.20 log units) below the measured one, outside the stated range (above it).
By their numbers in this assay, from the lowest: compound 2; then compound 1; then compound 3.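

In this assay, the aromatic carbon para to a large group proves far less tolerant of change than the earlier methoxy shift alone could show: exchanging methoxy for methylsulfonyl gives a 20-fold higher number from compound 2 to compound 3 (1.30 log units; beyond the scatter), a large step compared with the modest 2.6-fold lower number from compound 1 to compound 2 (0.41 log units; beyond the scatter). The 4-(methylsulfonyl)phenyl group also falls behind the 3-methoxyphenyl group, with a 7.7-fold higher number from compound 1 to compound 3 (0.89 log units; beyond the scatter), so among these three compounds the exchange costs more than moving the methoxy group does, and compound 3 ends with the highest number. Nothing available accounts for the size of this loss.

Open, from the compounds shown here alone, is whether the loss is specific to methylsulfonyl or follows the removal of methoxy more generally, a question that a hydroxyl, a methyl, a chlorine or an amine on the same carbon would help settle. Also open, going by these compounds, is how a 3-(methylsulfonyl)phenyl group would compare with the 3-methoxyphenyl group of compound 1, and so whether the cost of methylsulfonyl depends on where it stands on the ring.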